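A few compounds are considered here, and "the series" means these few. Any claim that something is new, unique, unknown or untested is made for them only; others in the source may bear on it.

Series notes. Compound 1 `Cc1nc2c(OCc3ccccc3)cccn2c1N` carries a benzyloxy-type link to its phenyl ring; compound 2 `Cc1nc2c(CCc3ccccc3)cccn2c1N` carries a two-carbon link instead, and the difference between the two cores is not broken down here. In a functional assay on the whole organism with Canis familiaris (Canis lupus familiaris) as the target, at a dose of 8 mg/kg by the oral route (a lower number here means a weaker effect, a higher number a stronger effect of the compound at the dose given), compound 1 gives 96% and compound 2 gives 52%. Compound 3 `CC(=O)Nc1c(C)nc2c(OCc3ccccc3)cccn12` is compound 1 with acetyl in place of hydrogen on a nitrogen on an aromatic ring; in this assay compound 3 gives 44%, so that a number 52 percentage points lower from compound 1 to compound 3 (beyond the scatter). Compound 4 `CC(=O)Nc1c(C)nc2c(CCc3ccccc3)cccn12` is compound 2 with acetyl in place of hydrogen on a nitrogen on an aromatic ring, the same change made on the other core, and awaits measurement in this assay. Going by the values given here, from compound 2 to compound 4 a step of a number 37 percentage points lower from compound 2 to compound 4 (beyond the scatter) is expected, resting on the single measured step of a number 52 percentage points lower from compound 1 to compound 3 (beyond the scatter) and on compound 2 starting lower at 52%. For compound 4 the estimate in this assay is 15%, expected between 0% and 40%.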

Compound 4, a percentage reported as inhibition, in the whole organism at one dose (the size of the read-out at that dose, not a potency): 16%
The estimate for compound 4 lay 1 percentage points below the measured number; the measured number falls inside the stated range.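

Amino to acetamido again lowers the read-out in this assay, with a number 36 percentage points lower from compound 2 to compound 4 (beyond the scatter). The direction of the change carries over from the core of compound 1 to the core of compound 2, but its size does not: the same change on two cores in this assay, a number 52 percentage points lower (beyond the scatter) from compound 1 to compound 3 and a number 36 percentage points lower (beyond the scatter) from compound 2 to compound 4, 16 percentage points apart, beyond the scatter of two such steps

Two cores at one dose give no rule for other cores, and these numbers do not show why the two steps differ in size.

On these data alone, only hydrogen and acetyl appear on this nitrogen, so a methyl group, a propionyl group or a methanesulfonyl group there remains open. Also open, as far as these compounds go, is how a longer chain in the link to the phenyl ring would behave, with the amine or with the acetamido group.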